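The source may hold more compounds than are shown below. What is called first, only, known or untested is meant among the compounds shown, and "the series" means these compounds.

Working notes on the series.

Three members of the series have been read in an assay on isolated protein (Cavia porcellus) with Sigma non-opioid intracellular receptor 1 (Homo sapiens) as the target, read by radioligand binding; on this read-out higher numbers stand for weaker inhibition and lower numbers for stronger inhibition. Compound 1 `CN(C)CCCCCCCCOc1ccc2oc(-c3ccccc3)cc(=O)c2c1` gives 227 nM in this assay; compound 2 `O=c1cc(-c2ccccc2)oc2ccc(OCCCCCCN3CCC(O)CC3)cc12` gives 100 nM; compound 3 `CCOC(=O)C1CCN(CCCCCCOc2ccc3oc(-c4ccccc4)cc(=O)c3c2)CC1` gives 164 nM. Compound 2 holds the lowest number of the three. Its gap to compound 3 is within the scatter, so the two cannot be ordered; the step of a 2.3-fold lower number from compound 1 to compound 2 (0.36 log units; beyond the scatter) is beyond the scatter and modest, while the step of a 1.4-fold lower number from compound 1 to compound 3 (0.14 log units; within the scatter) stays within the scatter, as does a 1.6-fold higher number from compound 2 to compound 3 (0.21 log units; within the scatter).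

All three measured steps concern the group on the saturated chain carbon six bonds along the chain from the oxygen on the aromatic ring; the shared core itself has not been varied. Compound 4 `O=c1cc(-c2cccs2)oc2ccc(OCCCCCCN3CCC(O)CC3)cc12` departs from compound 2 at the core instead: thiophen-2-yl in place of phenyl on an aromatic carbon. Among the compounds with values here, no measured step bears on this change, so nothing in the numbers so far argues for a shift in either direction, and a step no larger than the scatter is the working assumption. Compound 4 is therefore expected to give about 110 nM in this assay, within a range of 40 nM to 320 nM. The step this implies, a 1.1-fold higher number from compound 2 to compound 4 (0.04 log units; within the scatter), is an estimate only, resting on the absence of any contrary evidence rather than on a measured precedent.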

Compound 4, half-maximal inhibitory concentration: 119 nM
Compound 4: middle estimate off by 1.1-fold (0.03 log units), on the low side; low and high end bracket the measured number.
By their numbers in this assay, from the lowest: compounds 2, 4, 3 and 1 (each within the scatter of the next, the first and the last beyond it).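

Within the data shown here, the first measured change at the core, in this assay, is thiophen-2-yl in place of phenyl on the aromatic carbon next to the ring oxygen, and it gives a 1.2-fold higher number from compound 2 to compound 4 (0.08 log units; within the scatter) with the 4-hydroxypiperidin-1-yl chain end held fixed. The two compounds therefore cannot be ordered, and in this one pair the read-out does not separate a six-membered aromatic ring of carbon only from a five-membered aromatic ring with 1 hetero atom at this position. No measurement in hand bears on the reason for this result.

The compounds shown leave open whether thiophen-2-yl behaves the same way with the other chain ends, 4-(ethoxycarbonyl)piperidin-1-yl and the dimethylamino chain end of compound 1, since this single pair says nothing about how the core and the chain end act together. They also leave open whether other groups at this position, such as furan-2-yl, pyridin-2-yl or a phenyl carrying a carboxylic acid or an amine, stay within the scatter of compound 2 or move beyond it in either direction.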